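A few compounds are considered here, and "the series" means these few. Any claim that something is new, unique, unknown or untested is made for them only; others in the source may bear on it.

Three compounds have so far been put through a physicochemical assay for solubility, at pH 7.4 (a lower number here means a less soluble compound, a higher number a more soluble compound), and their numbers spread widely. Compound 1 `CC(C)COC(=O)OCCCS(=O)(=O)c1ccc(S(N)(=O)=O)s1` sits at the bottom with 80 ug/mL, and compound 2 `NS(=O)(=O)c1ccc(S(=O)(=O)CCCCO)s1` sits at the top with 9900 ug/mL. Compound 3 `CC(=O)OCCCc1ccc(S(N)(=O)=O)cc1` stands between them at 1600 ug/mL, the second highest of the three, and its gaps to both of the others lie beyond the usual scatter of repeated measurements.

The next compound to consider is compound 4 `CC(=O)OCCCCCc1ccc(S(N)(=O)=O)cc1`, which has not yet been measured. It differs from compound 3 in one place: 2-acetoxyethyl in place of acetoxy on a saturated chain carbon, three bonds along the chain from an aromatic carbon. In words, 2-acetoxyethyl stands in place of acetoxy on a saturated chain carbon, three bonds along the chain from an aromatic carbon.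

For the measured compounds named here, no two measured compounds differ in just one place, so the data offer no direct measure of this change, and any forecast is a judgement rather than a reading. The expectation here is a fall in the number, with the estimated move being a 4.6-fold lower number from compound 3 to compound 4 (0.66 log units; beyond the scatter), a step expected to lie beyond the scatter. For compound 4 the estimated value is 350 ug/mL, with an expected range from 100 ug/mL to 900 ug/mL.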

Compound 4, solubility: 1200 ug/mL
For compound 4 the middle estimate is 3.4-fold (0.54 log units) below the measured one, and the stated range ends below it.
By their numbers in this assay, from the lowest: compound 1; then compounds 4 and 3 (each within the scatter of the next); then compound 2.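

In this assay the step from acetoxy to 2-acetoxyethyl on a saturated chain carbon, three bonds along the chain from an aromatic carbon, gives a 1.3-fold lower number from compound 3 to compound 4 (0.12 log units; within the scatter) and so stays within the scatter, and the two compounds cannot be told apart on this read-out. For the compounds shown here, this is the first pair in the set that differs in only one place, so it gives the first direct reading of a change at this position: here, a group with more carbon atoms but the same hydrogen-bond donor and acceptor counts, no ring and no net charge enters without a difference that the assay can resolve. Nothing in hand gives a reason for this result.

A single step cannot show whether a still longer chain would also stay within the scatter, or whether an amine or a carboxylic acid in place of the acetoxy would separate from compound 3. It also leaves open whether the same change would give so small a step on a different core, such as that of compound 1.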